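Turning One Stereocentre at a Cytotoxicity Limit

This account rests on a few compounds, and the source may have more. Where it says the series, first, only, none or still open, it means among the compounds named here.

Compound 1 `COc1ccc(/C=C\c2cc(OC)c(OC)c(OC)c2)cc1OCc1ccc(CNC(C)(C)C(=O)O)cc1`, compound 2 `COc1ccc(/C=C\c2cc(OC)c(OC)c(OC)c2)cc1OCc1ccc(CN2C[C@H](O)C[C@@H]2C(=O)O)cc1` and compound 3 `COc1ccc(/C=C\c2cc(OC)c(OC)c(OC)c2)cc1OCc1ccc(CN2CCCC[C@H]2C(=O)O)cc1` share one core and differ in the group on a saturated chain carbon bound to an aromatic carbon. In an ADME assay on HEK293 cells (Homo sapiens) for cytotoxicity, read by CCK-8 assay, with a stated time of 48 h (on this read-out higher numbers stand for weaker inhibition and lower numbers for stronger inhibition), compound 1 gives > 50000 nM, which is a limit and not a number. Compound 2 gives > 50000 nM, again a limit. Compound 3 gives > 50000 nM, also a limit, so it has no numerical position within the set. The series as a whole stands at the limit of > 50000 nM in this assay, at which 3 of the 3 values shown sit.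

Compound 4 `COc1ccc(/C=C\c2cc(OC)c(OC)c(OC)c2)cc1OCc1ccc(CN2CCCC[C@@H]2C(=O)O)cc1` is related to compound 3 by a single change: the two compounds have the same atoms and bonds and differ only in configuration as drawn: 1 of 2 stereo elements differ; a stereocentre at a saturated ring carbon is drawn S in compound 3 and R in compound 4. The nearest measured evidence comes from changes to the same group. These are a step that the two limits leave unreadable from compound 1 to compound 3 and a step that the two limits leave unreadable from compound 2 to compound 3. Going by the values given here, neither gives a size to carry forward, and no measured pair isolates a change of configuration. With all three compounds at the same limit, no step beyond the scatter is expected in this assay, and no direction is favoured. The expected change is a number no higher from compound 3 to compound 4 (the limit leaves the size open). For compound 4 the estimate is 50000 nM. The expected range for compound 4 runs from 25000 nM to 100000 nM, and the assay will most likely report only a limit again.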

Compound 4, half-maximal inhibitory concentration: 42000 nM
Compound 4: middle estimate off by 1.2-fold (0.08 log units), on the high side; the measured number falls inside the stated range.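

In this assay, going by these compounds alone, compound 4 is the only member of the set to give a number and not a limit, and the sole difference from its partner is the drawn configuration at the saturated ring carbon, R in compound 4 and S in compound 3: the fact that compounds 3 and 4 differ only in the configuration as drawn. Within the data shown here, this gives the first readable step for a change of configuration at this position, an at least 1.1-fold lower number from compound 3 to compound 4 (0.07 log units; that floor lies within the scatter), and it fixes only a floor, so the direction of the step can be read while its true size cannot. The 2-carboxypiperidin-1-yl group in the R form also makes two comparisons readable as floors, an at least 1.1-fold lower number from compound 2 to compound 4 (0.07 log units; that floor lies within the scatter) and an at least 1.1-fold lower number from compound 1 to compound 4 (0.07 log units; that floor lies within the scatter), while the steps among the other three compounds still cannot be read, and most of the set stays at one limit: the limit of > 50000 nM in this assay, at which 3 of the 4 values shown sit.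

The compounds shown leave open how far the two forms of the 2-carboxypiperidin-1-yl group really lie apart, as compound 3 has only a limit. They also leave open whether a primary amide or a tetrazole in place of the carboxylic acid would give a number in this assay.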